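The source may hold more compounds than are shown below. What is called first, only, known or untested is meant among the compounds shown, and "the series" means these compounds.

Three compounds share one core and differ only in the group carried on the outer ring. Compound 1 `CCCCCCc1ccc(COc2cccc(C(=O)NO)c2)cc1` carries a hexyl group there and in an assay on isolated protein for inhibition of sphingomyelin phosphodiesterase (Homo sapiens), read by fluorescence, with a stated time of 30 min (on this read-out lower numbers stand for stronger inhibition and higher numbers for weaker inhibition), compound 1 gives 2110 nM. Compound 2 `O=C(NO)c1cccc(OCc2ccc(-c3ccc(Cl)cc3)cc2)c1` carries a 4-chlorophenyl group instead, and in this assay compound 2 gives 8960 nM. Compound 3 `O=C(NO)c1cccc(OCc2ccc(/C=C/c3ccccc3)cc2)c1` carries a 2-phenylethenyl group; for compound 3 this assay reports no number but only a limit, > 100000 nM, which is the limit of the limit of > 100000 nM in this assay, at which 1 of the 3 values shown sits. Compound 3 therefore stands at the weak end of the three, with an at least 47-fold higher number from compound 1 to compound 3 (1.67 log units; beyond the scatter) and an at least 11-fold higher number from compound 2 to compound 3 (1.04 log units; beyond the scatter).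

Compound 4 `CCc1nc(-c2ccc(COc3cccc(C(=O)NO)c3)cc2)no1` has not yet been measured. It differs from compound 3 in one place: 5-ethyl-1,2,4-oxadiazol-3-yl in place of 2-phenylethenyl on an aromatic carbon. The two measured steps that lead into compound 3 both show a large loss when the 2-phenylethenyl group enters at this position, so exchanging that group for a smaller heteroaromatic one is expected to recover part of the lost inhibition. The step from compound 3 to compound 4 in this assay is therefore expected to be an at least 8.3-fold lower number from compound 3 to compound 4 (0.92 log units; beyond the scatter), a move toward a measurable number. Compound 4 is estimated to give about 12000 nM in this assay, with a plausible range from 2500 nM to 60000 nM.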

Compound 4, half-maximal inhibitory concentration: 34700 nM
Compound 4: the middle estimate sits 2.9-fold (0.46 log units) below what was measured; low and high end bracket the measured number.
By their numbers in this assay, from the lowest: compound 1; then compound 2; then compound 4. At a limit, above all of these: compound 3.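

In this assay, compound 4 alone among the four carries a five-membered aromatic ring with 3 hetero atoms at this position, and this group gives a real number where the 2-phenylethenyl group gave none, with an at least 2.8-fold lower number from compound 3 to compound 4 (0.45 log units; beyond the scatter). Compound 3 holds only a limit, so this step gives a smallest size and no true size: the limit of > 100000 nM in this assay, at which 1 of the 4 values shown sits. The 5-ethyl-1,2,4-oxadiazol-3-yl group still falls short of both 4-chlorophenyl and hexyl, with a 3.9-fold higher number from compound 2 to compound 4 (0.59 log units; beyond the scatter) and a 16-fold higher number from compound 1 to compound 4 (1.22 log units; beyond the scatter), so among these four compounds, the ring with hydrogen-bond acceptors recovers only part of the ground and does not match the plain hexyl chain.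

The compounds shown leave open whether the gain over compound 3 belongs to the hetero atoms or to the loss of the double bond, a question that a 2-phenylethyl group at the same place could help to separate. Also open, going by these compounds, is whether an octyl chain, or a hexyl chain ending in an amine or a carboxylic acid, would improve on compound 1, at 2110 nM.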